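Swapping bromo for fluoro on compound 2

The source may report more compounds than this note shows. Statements on the series, on what has been measured and on what is new or still open speak of the compounds shown alone.

Of the compounds shown here, two have been measured in an ADME assay on HEK-293T cells (Homo sapiens) for cytotoxicity, read by MTT assay, with a stated time of 48 h, in the presence of a further agent that is not named here; a lower number here means a stronger inhibitor, a higher number a weaker inhibitor. Compound 1 `COc1ccc2[nH]cc(-c3nc(C(=O)Nc4cc(OC)c(OC)c(OC)c4)cs3)c2c1` gives 8740 nM, and compound 2 `COc1cc(NC(=O)c2csc(-c3c[nH]c4ccc(Br)cc34)n2)cc(OC)c1OC` gives 32800 nM, the higher of the two numbers. Going by the values given here, the one step seen so far, a 3.8-fold higher number from compound 1 to compound 2 (0.57 log units; beyond the scatter), changed the group at the same place. Compound 3 `COc1cc(NC(=O)c2csc(-c3c[nH]c4ccc(F)cc34)n2)cc(OC)c1OC` carries fluoro in place of bromo on an aromatic carbon. Among the compounds with values here, no measured step swaps one halogen for another, so that earlier step is only a loose guide and no clear direction can be read from it. The expected step is a 1.6-fold lower number from compound 2 to compound 3 (0.21 log units; within the scatter). Compound 3 is estimated at 20000 nM, with a range from 7000 nM to 60000 nM.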

Compound 3, half-maximal inhibitory concentration: 66000 nM
For compound 3 the middle estimate is 3.3-fold (0.52 log units) below the measured one, and the stated range ends below it.
By their numbers in this assay, from the lowest: compound 1; then compounds 2 and 3 (each within the scatter of the next).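

Within this assay the halogen swap on the indole, 5-bromo-1H-indol-3-yl to 5-fluoro-1H-indol-3-yl, gives a step that does not separate bromo from fluoro (a 2.0-fold higher number from compound 2 to compound 3 (0.30 log units; within the scatter)). Methoxy now stands apart from both halogens, not from bromo alone, since fluoro in its place also gives a clear step (a 7.6-fold higher number from compound 1 to compound 3 (0.88 log units; beyond the scatter)). No measured finding accounts for this gap between methoxy and the halogens. Going by these compounds, whether an amine or a longer chain such as ethoxy at this carbon would match methoxy or the halogens stays open.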